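The source may hold more compounds than are shown below. What is called first, only, known or untested is meant among the compounds shown, and "the series" means these compounds.

In a functional assay on M21 cells (Homo sapiens) for antiproliferative activity, read by sulforhodamine B assay, with a stated time of 48 h (a higher number here means a weaker inhibitor, a lower number a stronger inhibitor), compound 1, `COc1cccc(OS(=O)(=O)c2ccc(N3CCN(C)C3=O)cc2)c1`, gives 1600 nM. Compound 2, `COc1ccc(OS(=O)(=O)c2ccc(N3CCN(C)C3=O)cc2)cc1OC`, carries methoxy in place of hydrogen on an aromatic carbon and gives 8500 nM in this assay; that change made a 5.3-fold higher number from compound 1 to compound 2 (0.73 log units; beyond the scatter). Compound 3, `CCN1CCN(c2ccc(S(=O)(=O)Oc3cc(OC)cc(OC)c3)cc2)C1=O`, gives 4200 nM in this assay; the difference between its core and the core of compound 1 is not broken down here. Compound 4, `CCN1CCN(c2ccc(S(=O)(=O)Oc3cc(OC)c(OC)c(OC)c3)cc2)C1=O`, differs from compound 3 by methoxy in place of hydrogen on an aromatic carbon. This is the same kind of change as the one seen before, though here the entering group sits ortho to two methoxy groups, whereas earlier it sat ortho to a methoxy group. Should it behave alike, the estimated step in this assay is a 3.8-fold higher number from compound 3 to compound 4 (0.58 log units; beyond the scatter), resting on a 5.3-fold higher number from compound 1 to compound 2 (0.73 log units; beyond the scatter). Compound 4 is therefore expected to give 16000 nM, within 6000 nM to 45000 nM.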

Compound 4, half-maximal inhibitory concentration: 870 nM
Compound 4: the middle estimate sits 18-fold (1.26 log units) above what was measured; the measured number lies below the stated range.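

In this assay, methoxy in place of hydrogen on an aromatic carbon made a 4.8-fold lower number from compound 3 to compound 4 (0.68 log units; beyond the scatter). Set beside the earlier step, the same change went the opposite way, so in this series its effect on one core cannot simply be carried to another: the same change on two cores in this assay, a 5.3-fold higher number (0.73 log units; beyond the scatter) from compound 1 to compound 2 and a 4.8-fold lower number (0.68 log units; beyond the scatter) from compound 3 to compound 4, 26-fold (1.41 log units) apart, beyond the scatter of two such steps This rests on one pair of compounds for each core, and the two pairs differ in more than one place, so it does not show which difference goes with the reversal.

The compounds shown leave open whether an ethoxy group or a chlorine atom in that place would follow the same direction as methoxy. Also open, from the compounds shown here alone, is whether the direction would hold with methyl in place of ethyl on the core of compound 3.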